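From ethyl to propyl in a nitro-bearing series

A few compounds are considered here, and "the series" means these few. Any claim that something is new, unique, unknown or untested is made for them only; others in the source may bear on it.

compound 1 `C/N=C(/S)C1=CC(C)(C)Oc2ccc(C#N)cc21` gives 24.6 nM
compound 2 `C/N=C(/S)C1=CC(C)(C)Oc2ccc([N+](=O)[O-])cc21` gives 1.35 nM
compound 3 `CCC1(C)C=C(/C(S)=N\C)c2cc([N+](=O)[O-])ccc2O1` gives 0.182 nM

All three values come from a functional assay (aorta) with Rattus norvegicus as the target (on this read-out higher numbers stand for an effect only at larger amounts of compound and lower numbers for an effect already at smaller amounts), and compound 3 holds the lowest number among them, with both other compounds beyond the scatter from it. The next compound to be measured is compound 4 `CCCC1(C)C=C(/C(S)=N\C)c2cc([N+](=O)[O-])ccc2O1` and it differs from compound 3 in one place (methyl in place of hydrogen on a saturated chain carbon, two bonds along the chain from a saturated ring carbon). Put another way, the ethyl of compound 3 becomes a propyl in compound 4.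

Among the measured compounds shown here, the closest precedent is a 7.4-fold lower number from compound 2 to compound 3 (0.87 log units; beyond the scatter) and it came from methyl to ethyl on the carbon bound to the saturated ring carbon. The other measured step, an 18-fold lower number from compound 1 to compound 2 (1.26 log units; beyond the scatter), concerns nitro in place of cyano on an aromatic carbon and has little bearing here. A single lengthening cannot show whether the trend continues, and no longer chain has been measured. Going by these compounds, no step beyond the scatter is therefore expected, although either direction remains open. The estimate means an expected 1.4-fold higher number from compound 3 to compound 4 (0.14 log units; within the scatter) in this assay as the central case. Compound 4 is expected at 0.25 nM with an estimated range from 0.06 nM to 1 nM as the likely spread.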

Compound 4, half-maximal effective concentration: 0.017 nM
Compound 4: the middle estimate sits 15-fold (1.17 log units) above what was measured, outside the stated range (below it).
By their numbers in this assay, from the lowest: compound 4; then compound 3; then compound 2; then compound 1.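

In this assay, lengthening ethyl to propyl gives a second clear fall in the number (an 11-fold lower number from compound 3 to compound 4 (1.03 log units; beyond the scatter)). The fall seen on going from methyl to ethyl (a 7.4-fold lower number from compound 2 to compound 3 (0.87 log units; beyond the scatter)) is therefore not confined to the saturated chain carbon bound to a saturated ring carbon, and it continues on a saturated chain carbon, two bonds along the chain from a saturated ring carbon. Taken as a whole, the change from methyl to propyl amounts to a much larger step (a 79-fold lower number from compound 2 to compound 4 (1.90 log units; beyond the scatter)), and across compound 2, compound 3 and compound 4 the number falls with each added methyl, with none of these three going against the run, while no measurement shown here offers an explanation for it.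

Three chain lengths cannot tell whether a butyl or a still longer chain would carry the fall further, halt it or reverse it, nor whether a branched group such as isopropyl would behave like propyl. Going by these compounds, it also remains open whether the same lengthening would lower the number on the nitrile-bearing core of compound 1, where only the methyl member appears here.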